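A few compounds are considered here, and "the series" means these few. Any claim that something is new, unique, unknown or untested is made for them only; others in the source may bear on it.

The three measured compounds share one core, carried in compound 3 `COc1ccc(-n2sc(=O)n(Cc3ccccc3)c2=O)cc1`. In an ADME assay, in phosphate buffer, with a stated time of 30 min, tested at 1 mM, at a dose of 1 mM, in the presence of a further agent that is not named here (a higher number here means more compound in the circulation at the dose given, a lower number less compound in the circulation), compound 3 gives 5910 nM, the lowest of the three numbers measured. Compound 1 `COc1ccc(-n2sc(=O)n(C3CCCCC3)c2=O)cc1` gives 36300 nM in this assay, and the step of a 6.1-fold lower number from compound 1 to compound 3 (0.79 log units; beyond the scatter) lies beyond the scatter. Among the measured compounds shown here, compound 2 `COc1ccc(-n2sc(=O)n(-c3ccc(OC)cc3)c2=O)cc1`, which carries 4-methoxyphenyl on an aromatic nitrogen, gives 31100 nM in this assay; no step between compound 2 and compound 3 has been computed, but the two values stand well apart, with compound 3 below.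

The change to compound 4 `COc1ccc(-n2sc(=O)n(-c3ccc(Cl)cc3)c2=O)cc1` is 4-chlorophenyl in place of benzyl on an aromatic nitrogen. For the measured compounds named here, the one measured step that touches this position, a 6.1-fold lower number from compound 1 to compound 3 (0.79 log units; beyond the scatter), shows that the group on the aromatic nitrogen moves the read-out by more than the scatter, and the value of compound 2, 31100 nM, shows a six-membered aromatic ring bound directly to that nitrogen standing near compound 1 rather than near compound 3. Compound 4 likewise binds a six-membered aromatic ring directly to that nitrogen, so a rise in this assay is expected, of size a 3.4-fold higher number from compound 3 to compound 4 (0.53 log units; beyond the scatter). Going by the values given here, no measured pair shows chlorine in place of methoxy, so the range is kept wide. Compound 4 is therefore estimated at 20000 nM in this assay, between 6000 nM and 50000 nM.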

Compound 4, maximal plasma concentration: 35700 nM
Compound 4: middle estimate off by 1.8-fold (0.25 log units), on the low side; the measured number falls inside the stated range.
By their numbers in this assay, from the lowest: compound 3; then compounds 2, 4 and 1 (each within the scatter of the next).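

In this assay, putting 4-chlorophenyl in place of benzyl on the aromatic nitrogen gives a 6.0-fold higher number from compound 3 to compound 4 (0.78 log units; beyond the scatter), so the low number of compound 3 does not carry over to this group, even though the entering and leaving groups have the same heavy-atom count and each holds one six-membered aromatic ring. Among the compounds shown here, the result also gives the first reading of chloro in place of methoxy on an aromatic carbon: a 1.1-fold higher number from compound 2 to compound 4 (0.06 log units; within the scatter) shows no difference that can be told from the scatter. With 4-chlorophenyl in place of cyclohexyl, a 1.0-fold lower number from compound 1 to compound 4 (0.01 log units; within the scatter) likewise stays within the scatter, so compound 4 matches both compound 1 and compound 2, and among these compounds only compound 3, with benzyl, stands apart.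

From the compounds shown here alone, it remains open whether a longer chain such as phenethyl, or an amine or a carboxylic acid on the ring of the benzyl group, would stay with compound 3 or join compound 4. Nothing given here accounts for the separate position of benzyl in this read-out.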